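Series notes: nitro in place of methoxy, compound 4

The source may hold more compounds than are shown below. What is called first, only, known or untested is meant among the compounds shown, and "the series" means these compounds.

Measured so far:
- compound 1, `COc1ccccc1/N=N/C(=N/NC(=O)c1cc(O)c(O)c(O)c1)c1ccccc1`: 52.7%
- compound 2, `Cc1ccccc1/N=N/C(=N/NC(=O)c1cc(O)c(O)c(O)c1)c1ccccc1`: 41.5%
- compound 3, `O=C(N/N=C(/N=N/c1ccc([N+](=O)[O-])cc1)c1ccccc1)c1cc(O)c(O)c(O)c1`: 34.6%

All three were run in an ADME assay on RAW264.7 cells (Mus musculus) for inhibition, read by MTT assay, with a stated time of 72 h, tested at 100 uM; a higher number here means more inhibition of growth at the concentration tested, a lower number less inhibition of growth. Compound 1 stands highest of the three numbers; its steps to compound 2 and to compound 3 both lie beyond the scatter, so on these numbers it is the most inhibitory of the set.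

The next compound is compound 4, `O=C(N/N=C(/N=N/c1ccccc1[N+](=O)[O-])c1ccccc1)c1cc(O)c(O)c(O)c1`. Relative to compound 1 the change is nitro in place of methoxy on an aromatic carbon.

Going by the values given here, two measured steps bear on this. Exchanging the methoxy of compound 1 for a methyl at the same aromatic carbon gave a number 11.2 percentage points lower from compound 1 to compound 2 (beyond the scatter). Exchanging the whole 2-methoxyphenyl for 4-nitrophenyl gave a number 18.1 percentage points lower from compound 1 to compound 3 (beyond the scatter). Both replacements of the methoxy lowered the number by a modest amount, and the nitro-bearing analogue gave the lowest value of the three. Among the compounds with values here, no compound in the set shows a replacement of the methoxy that raised the number.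

A modest fall from compound 1 is therefore expected for compound 4, of the order a number 12.7 percentage points lower from compound 1 to compound 4 (beyond the scatter). Compound 4 is estimated at 40%, within 28% to 52%.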

Compound 4, percent growth inhibition at one concentration: 5.43%
Beside the measured number, compound 4's estimate is 34.6 percentage points above it, outside the stated range (below it).
By their numbers in this assay, from the lowest: compound 4; then compounds 3 and 2 (each within the scatter of the next); then compound 1.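

In this assay the aromatic carbon ortho to a large group proves far from indifferent to what it carries: nitro in place of methoxy gives a number 47.3 percentage points lower from compound 1 to compound 4 (beyond the scatter) and nitro in place of methyl gives a number 36.1 percentage points lower from compound 2 to compound 4 (beyond the scatter) and both steps are large, where the steps among the first three compounds were modest or within the scatter. The presence of a nitro group alone does not set the number, since 2-nitrophenyl in place of 4-nitrophenyl gives a number 29.2 percentage points lower from compound 3 to compound 4 (beyond the scatter) and the two compounds differ only in where the nitro sits. Nothing at hand accounts for the size of these falls.

Still open, on these data alone, is whether the low number belongs to nitro alone at this carbon or would also appear with an amine, a carboxylic acid or a nitrile there. Also open, as far as these compounds go, is whether the higher number of compound 1 is particular to methoxy, which an ethoxy, a longer alkoxy chain or a hydroxyl at the same carbon would test, and whether the 4-methoxyphenyl analogue would keep it.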